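The compounds below may be only part of what the source reports. "The series", "measured", "known", "first", "only" and "open" are said of these compounds alone.

The shared core, carrying a butyl chain and a biphenyl bearing a tetrazole, appears in all four compounds here. For compound 1 `CCCCc1nc(CCC)c(CCC(=O)OCC)c(=O)n1Cc1ccc(-c2ccccc2-c2nnn[nH]2)cc1` the entry in an in vivo functional assay on the whole organism for inhibition, with Rattus norvegicus as the target (a lower number here means that less compound is needed, a higher number that more compound is needed for the effect), reads "not determined" (no result reported), so no result exists for it. Compound 2 `CCCCc1nc(C)c(CC(=O)N(CC)CC)c(=O)n1Cc1ccc(-c2ccccc2-c2nnn[nH]2)cc1` gives 0.089 mg/kg in this assay, and compound 3 `CCCCc1nc(C)c(CC(=O)N2CC(C)OC(C)C2)c(=O)n1Cc1ccc(-c2ccccc2-c2nnn[nH]2)cc1` gives 0.029 mg/kg. On these numbers compound 2 stands with the highest number of the two, needing more compound than compound 3. Among the compounds with values here, the single measured step, a 3.1-fold lower number from compound 2 to compound 3 (0.49 log units; beyond the scatter), shows that swapping an open-chain amine on the carbonyl for a ring amine lowered the dose beyond the scatter.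

Compound 4 `CCCCc1nc(C)c(CCC(=O)N2CCSCC2)c(=O)n1Cc1ccc(-c2ccccc2-c2nnn[nH]2)cc1` differs from compound 2 by ((thiomorpholin-4-yl)carbonyl)methyl in place of diethylcarbamoyl on a saturated chain carbon bound to an aromatic carbon. Like compound 3, it places a six-membered ring with two hetero atoms on the carbonyl, but the chain to the core is one carbon longer and the ring holds a sulfur rather than an oxygen. Within the data shown here, only the step from compound 2 to compound 3 bears on this change, and it was modest. Among the measured compounds shown here, because of a 3.1-fold lower number from compound 2 to compound 3 (0.49 log units; beyond the scatter), the ring amide is expected to help, while the longer chain has no measured counterpart, so a smaller gain is expected. Compound 4 is estimated to give 0.05 mg/kg in this assay, between 0.02 mg/kg and 0.15 mg/kg, which would be a step of a 1.8-fold lower number from compound 2 to compound 4 (0.25 log units; within the scatter).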

Compound 4, dose for half-maximal effect: 0.204 mg/kg
Estimate against measurement, compound 4: 4.1-fold (0.61 log units) below; measured number above the stated range.
By their numbers in this assay, from the lowest: compound 3; then compound 2; then compound 4.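

Compound 4 shows that placing a ring amide at this position does not by itself lower the dose needed in this assay: replacing (diethylcarbamoyl)methyl with 2-((thiomorpholin-4-yl)carbonyl)ethyl gives a 2.3-fold higher number from compound 2 to compound 4 (0.36 log units; beyond the scatter) and so runs opposite to a 3.1-fold lower number from compound 2 to compound 3 (0.49 log units; beyond the scatter) in direction. The two ring amides also lie far apart, with a 7.0-fold higher number from compound 3 to compound 4 (0.85 log units; beyond the scatter) as the largest step in this set, so the earlier gain does not carry over to every group with a six-membered ring on the carbonyl. No measurement available here explains the rise.

Compound 4 combines a chain that is one carbon longer with a different ring, and these steps cannot show how much of the rise belongs to the chain and how much to the ring. From the compounds shown here alone, a (thiomorpholin-4-yl)carbonyl group on the shorter methyl chain or a 2-((2,6-dimethylmorpholin-4-yl)carbonyl)ethyl group would pull these two changes apart, and the effect of a carboxylic acid at the end of the chain also remains open.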